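Replacing 4-bromophenyl on the shared core: compound 1 to compound 3

This account rests on a few compounds, and the source may have more. Where it says the series, first, only, none or still open, it means among the compounds named here.

- compound 1 `OC[C@H]1O[C@@H](n2cnc3c(NCc4ccc(Br)cc4)ncnc32)[C@H](O)[C@@H]1O` gives 20600 nM
- compound 2 `OC[C@H]1O[C@@H](n2cnc3c(NCc4ccc(Cl)cc4Cl)ncnc32)[C@H](O)[C@@H]1O` gives 86700 nM
- compound 3 `COc1cccc(CNc2ncnc3c2ncn3[C@@H]2O[C@H](CO)[C@@H](O)[C@H]2O)c1OC` is not yet measured

In a functional assay on CCRF-CEM cells (Homo sapiens) for antiproliferative activity, with a stated time of 72 h (a higher number here means a weaker inhibitor, a lower number a stronger inhibitor), compound 1 (20600 nM) holds the lower of the two numbers. Compound 3 carries one change (2,3-dimethoxyphenyl in place of 4-bromophenyl on a saturated chain carbon bound to a nitrogen on an aromatic ring): 2,3-dimethoxyphenyl in place of 4-bromophenyl. Going by the values given here, one measured step bears on it, the modest replacement of the same group in compound 2 (a 4.2-fold higher number from compound 1 to compound 2 (0.62 log units; beyond the scatter)), which lies beyond the scatter. A single step is thin evidence, but a similarly modest rise is expected (a 1.9-fold higher number from compound 1 to compound 3 (0.29 log units; within the scatter)) in this assay as well. For compound 3 the estimated value is 40000 nM (expected range 14000 nM to 110000 nM).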

Compound 3, half-maximal inhibitory concentration: > 166000 nM
Compound 3: a limit, no number (the forecaster's own chance of this, stated with the estimate: 15%); at least 4.1-fold (0.61 log units) between middle value and limit.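

In this assay, the value of compound 3 is a limit, not a number: the limit of > 166000 nM in this assay, at which 1 of the 3 values shown sits.

On a saturated chain carbon bound to a nitrogen on an aromatic ring, 2,3-dimethoxyphenyl in place of 4-bromophenyl gives an at least 8.0-fold higher number from compound 1 to compound 3 (0.90 log units; beyond the scatter), so this position tolerates this change poorly in the assay. In place of 2,4-dichlorophenyl, the same group gives an at least 1.9-fold higher number from compound 2 to compound 3 (0.28 log units; that floor lies within the scatter), which leaves the order of these two compounds unsettled.

The compounds shown do not separate the contributions of the two methoxy groups. As far as these compounds go, how an amine or a carboxylic acid on the phenyl ring would read here also remains open.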